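The compounds below may be only part of what the source reports. "The series", "measured", "known", "first", "only" and "open" are said of these compounds alone.

Of the compounds shown here, three sharing one core have been measured in an ADME assay on Vero cells (Chlorocebus sabaeus) for cytotoxicity, with a stated time of 7 days; a higher number here means that more compound is tolerated, a lower number that less compound is tolerated. Compound 1 `COc1ccc2[nH]c(C(=O)N3CC(=O)N(Cc4ccc[nH]4)[C@@H](Cc4ccccc4)C3)cc2c1` gives 15200 nM in this assay. Compound 2 `COc1cccc(CN2C(=O)CN(C(=O)c3cc4cc(OC)ccc4[nH]3)C[C@@H]2CCc2ccccc2)c1` gives 4500 nM. Compound 3 `COc1ccc2[nH]c(C(=O)N3CC(=O)N(Cc4ccccc4)[C@@H](COC(C)(C)C)C3)cc2c1` gives 78200 nM, the highest of the three numbers; its nearest neighbour is compound 1, and that gap is beyond the scatter, as is the wider gap to compound 2. Compound 3 is thus the best tolerated of the three.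

Compound 4 `COc1ccc2[nH]c(C(=O)N3CC(=O)N(Cc4ccccc4)[C@@H](CN4CC5CCCC5C4)C3)cc2c1` has not yet been measured. It differs from compound 3 in one place: a group of 8 heavy atoms (7 carbon, 1 nitrogen; one five-membered non-aromatic ring of carbon only, one five-membered non-aromatic ring with 1 hetero atom) in place of a group of 5 heavy atoms (4 carbon, 1 oxygen; no ring), on a saturated chain carbon bound to a saturated ring carbon. Going by the values given here, no measured pair shows this kind of change, so there is no step to lean on, and the expectation rests on the structures alone. The step of a 3.9-fold lower number from compound 3 to compound 4 (0.59 log units; beyond the scatter) is expected to run downward, toward less compound being tolerated, and to reach beyond the scatter, though with wide uncertainty. Compound 4 is estimated at 20000 nM in this assay, with a range from 6000 nM to 60000 nM.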

Compound 4, half-maximal cytotoxic concentration: 10600 nM
For compound 4 the middle estimate is 1.9-fold (0.28 log units) above the measured one, and the stated range covers the measured number.
By their numbers in this assay, from the lowest: compound 2; then compounds 4 and 1 (each within the scatter of the next); then compound 3.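

Going by these compounds alone, this saturated chain carbon bound to a saturated ring carbon is the first place where a single change can be read. In this assay, putting the group with two five-membered rings in place of tert-butoxy gives a 7.4-fold lower number from compound 3 to compound 4 (0.87 log units; beyond the scatter). A change at this one position is therefore enough to move the number beyond the scatter, though nothing measured here says why it falls.

Within the data shown here, with only one step at this position, it stays open whether the fall goes with the ring nitrogen, with the rings themselves or with the larger group. A small open-chain amine such as dimethylamino, a hydroxyl group or a longer carbon chain on the same carbon could help tell these apart.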